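Turning One Ring Centre in a Fluorocyclopropyl Amide

The source may hold more compounds than are shown below. What is called first, only, known or untested is meant among the compounds shown, and "the series" means these compounds.

Of the compounds shown here, three built on one shared core have been tested in an assay on CHO cells for agonist activity at Neuronal acetylcholine receptor; alpha3/alpha6/beta2/beta3 (Homo sapiens), read by FLIPR and calcium flux; a higher number here means a larger maximal response, a lower number a smaller maximal response. Compound 1 `CC(=O)N1CC2CC(C1)N2` gives 100% in this assay. Compound 2 `CCCC(=O)N1CC2CC(C1)N2` gives 92%. Compound 3 `O=C([C@H]1C[C@H]1F)N1CC2CC(C1)N2` gives 130%, the highest of the three, with compound 1 nearest to it and compound 2 furthest away. Putting ethyl in place of hydrogen on the chain gave a number 8 percentage points lower from compound 1 to compound 2 (within the scatter). Putting 2-fluorocyclopropyl in place of methyl gave a number 30 percentage points higher from compound 1 to compound 3 (beyond the scatter), and in place of propyl gave a number 38 percentage points higher from compound 2 to compound 3 (beyond the scatter).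

Among the compounds with values here, compound 4 `O=C([C@@H]1C[C@H]1F)N1CC2CC(C1)N2` is the next compound. the two compounds have the same atoms and bonds; at least one stereo element is drawn with a configuration in one of them and without one in the other: 1 of 4 stereo elements differ; a stereocentre at a saturated ring carbon is drawn R in compound 3 and S in compound 4 All three measured steps change which group sits on the carbonyl carbon; none of them turns a ring stereocentre, so no measured step bears directly on this change. The size of the step in this assay from compound 3 to compound 4 is therefore uncertain, and the step is expected to be a number 20 percentage points lower from compound 3 to compound 4 (beyond the scatter), with a fall at least as likely as no change. Compound 4 is estimated at 110%, within a range from 75% to 140%.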

Compound 4, largest response reached (Emax), in percent of the reference or control that the assay uses: 130%
Estimate against measurement, compound 4: 20 percentage points below, and the stated range covers the measured number.
By their numbers in this assay, from the lowest: compounds 2 and 1 (each within the scatter of the next); then compounds 3 and 4 (each within the scatter of the next).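

Turning this one ring stereocentre from R to S gave no change at the digits printed from compound 3 to compound 4 (within the scatter) in this assay, so at this position the response does not follow the drawn configuration. The gain from 2-fluorocyclopropyl on the carbonyl carbon holds for both drawn forms, with a number 38 percentage points higher from compound 2 to compound 4 (beyond the scatter) in place of propyl and a number 30 percentage points higher from compound 1 to compound 4 (beyond the scatter) in place of methyl. One caution limits how far this pair can speak for two fully defined, opposite forms: the fact that one of compounds 3 and 4 is drawn with a defined configuration and the other without, at the place where they differ.

The compounds shown do not separate the fluorine from the three-membered ring that carries it, and an unsubstituted cyclopropyl group on the carbonyl carbon would make that separation. Going by these compounds, whether a 2-chlorocyclopropyl group would give the same response in either configuration also remains open.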